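Compound 3 and Its 4-Carboxycyclohexyl Group

The source may hold more compounds than are shown below. What is called first, only, known or untested is meant among the compounds shown, and "the series" means these compounds.

Of the compounds shown here, two have so far been measured in a functional assay on NCI-H929 cells (Homo sapiens) for antiproliferative activity, with a stated time of 24 h; a higher number here means a weaker inhibitor, a lower number a stronger inhibitor. Compound 1 `COc1ccc(F)cc1-c1ccnc2[nH]c(C3=CCC(N[C@@H](C(=O)O)C(C)C)CC3)cc12` gives 76 nM. Compound 2 `COc1ccc(F)cc1-c1c(F)cnc2[nH]c(C3=CCN([C@H]4CC[C@@H](CC(=O)O)CC4)CC3)cc12` gives 48 nM. These two values lie within the usual scatter of each other, so compound 2 stands level with compound 1 on the numbers available, and neither can be ranked above the other.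

Compound 3 `COc1ccc(F)cc1-c1c(F)cnc2[nH]c(C3=CCN([C@H]4CC[C@H](C(=O)O)CC4)CC3)cc12` has yet to be tested. It differs from compound 2 in one place: a group of 9 heavy atoms (7 carbon, 2 oxygen; one six-membered non-aromatic ring of carbon only) in place of a group of 10 heavy atoms (8 carbon, 2 oxygen; one six-membered non-aromatic ring of carbon only), on an amine nitrogen in a ring. The 4-carboxycyclohexyl group, of 9 heavy atoms, sits on an amine nitrogen in a ring, in place of a group of 10 heavy atoms.

For the measured compounds named here, no measured pair isolates a change of this kind, so the expectation rests on thin evidence. Compound 1 at 76 nM differs from compound 2 at 48 nM in more than one place, yet the two values remain within the scatter. No shift beyond the scatter is therefore expected in this assay, and no direction is favoured. The estimated change is a 1.1-fold higher number from compound 2 to compound 3 (0.06 log units; within the scatter). For compound 3 the expected value is 55 nM, with an estimated range of 20 nM to 150 nM.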

Compound 3, half-maximal inhibitory concentration: 40 nM
Estimate against measurement, compound 3: 1.4-fold (0.14 log units) above; the range from low to high includes it.
By their numbers in this assay, from the lowest: compounds 3, 2 and 1 (each within the scatter of the next).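

For the compounds shown here, this is the first pair in the account that differs in one place only, and it gives a direct reading at the amine nitrogen in a ring: in this assay, putting the 4-carboxycyclohexyl group in place of the group of 10 heavy atoms gives a 1.2-fold lower number from compound 2 to compound 3 (0.08 log units; within the scatter). Compound 2 and compound 3 therefore stand level, and this one exchange, between two groups that each carry a six-membered non-aromatic ring of carbon only and a carboxylic acid, is not told apart by this measurement, something the earlier comparison of compound 1 with compound 2 could not show because those two differ in more than one place. No further measurement is available here that bears on why the two compounds stand level.

The compounds shown leave open what happens at this nitrogen when the carboxylic acid is absent, as it would be with a plain cyclohexyl group or with a primary amide in its place. They also leave open whether a longer chain between the ring of carbon and the carboxylic acid, or an open-chain group on the nitrogen, would stay level with compound 2 and compound 3.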